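The compounds below may be only part of what the source reports. "The series", "measured", "known", "first", "only" and "open" are said of these compounds alone.

Compound 3, `COc1cc(OC)c(C(=O)/C=C/c2ccc(Cl)cc2)c(OC)c1`, was tested in a functional assay on MDA-MB-231 cells (Homo sapiens), read by fluorescence and BrdU incorporation, with a stated time of 48 h, tested at 10 uM (a lower number here means a stronger effect, a higher number a weaker effect of the compound at the concentration tested), and gave 39%. Its nearest neighbour among the measured compounds is compound 2, `COc1cc(OC)c(C(=O)/C=C/c2ccccc2)c(OC)c1`, which gave 37%; the step of a number 2 percentage points higher from compound 2 to compound 3 (within the scatter), chloro in place of hydrogen on an aromatic carbon, lies within the scatter. Compound 1, `COc1cc(O)c(C(=O)/C=C/c2ccc(F)cc2)c(OC)c1`, was reported as "not active" (no number reported) and so offers no number. Compound 4, `COc1cc(OC)c(C(=O)/C=C/c2ccc(F)cc2)c(OC)c1`, differs from compound 3 by fluoro in place of chloro on an aromatic carbon. Among the measured compounds shown here, no measured step involves this swap; the only step known, a number 2 percentage points higher from compound 2 to compound 3 (within the scatter), shows that a halogen at this position left the read-out essentially unchanged. The step is therefore expected to be a number 1 percentage points higher from compound 3 to compound 4 (within the scatter), not beyond the scatter. Compound 4 is expected to give about 40%, between 25% and 55%.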

Compound 4, a percentage reported as activity, at one concentration (the size of the read-out at that concentration, not a potency): 43%
Beside the measured number, compound 4's estimate is 3 percentage points below it; low and high end bracket the measured number.
By their numbers in this assay, from the lowest: compounds 2, 3 and 4 (each within the scatter of the next).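

In this assay, the swap of 4-chlorophenyl to 4-fluorophenyl gives a number 4 percentage points higher from compound 3 to compound 4 (within the scatter), and fluoro in place of hydrogen on the same aromatic carbon gives a number 6 percentage points higher from compound 2 to compound 4 (within the scatter). Hydrogen, chloro and fluoro at this place on the ring thus read alike, with no step among the three compounds leaving the scatter. Nothing available bears on what lies behind these readings. The compounds shown leave open whether a group other than a halogen here, such as an amine or a carboxylic acid, would shift the read-out beyond the scatter.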